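The compounds below may be only part of what the source reports. "The series", "measured", "known", "first", "only" and "open" are said of these compounds alone.

Measured in an ADME assay on Vero cells (Chlorocebus sabaeus) for cytotoxicity, read by MTT assay, with a stated time of 72 h; a lower number here means a stronger inhibitor, a higher number a weaker inhibitor:
compound 1 `COc1ccc(-c2ccnc(Nc3ccc(C(=O)O)cc3)n2)cc1`: > 100000 nM
compound 2 `COc1ccc(-c2ccnc(Nc3ccc(C(N)=O)cc3)n2)cc1`: 5400 nM
compound 3 `COc1ccc(-c2ccnc(Nc3ccc(S(N)(=O)=O)cc3)n2)cc1`: 2400 nM

Compound 1 stands at the limit of > 100000 nM in this assay, at which 1 of the 3 values shown sits, and this is a limit rather than a number.

Compound 4 `Cc1csc(-c2ccnc(Nc3ccc(C(=O)O)cc3)n2)c1` comes from compound 1 by one change: 4-methylthiophen-2-yl in place of 4-methoxyphenyl on an aromatic carbon of a six-membered aromatic ring with 2 nitrogen (4-methylthiophen-2-yl in place of 4-methoxyphenyl on an aromatic carbon). The carboxy group of compound 1 stays in place.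

Within the data shown here, none of the measured steps touches the 4-methoxyphenyl group, so they bear on this change only indirectly. All three concern the other substituent. The two that leave the carboxy group are large: an at least 18-fold lower number from compound 1 to compound 2 (1.26 log units; beyond the scatter) and an at least 41-fold lower number from compound 1 to compound 3 (1.61 log units; beyond the scatter). The step between the two replacements is modest: a 2.3-fold lower number from compound 2 to compound 3 (0.35 log units; beyond the scatter).

Compound 4 keeps the carboxy group, whose replacement in compound 1 gave an at least 41-fold lower number from compound 1 to compound 3 (1.61 log units; beyond the scatter), so a reading in the region of the limit is expected in this assay. No step beyond the scatter is expected, although the limit leaves any shift upward unseen and only a shift to a lower number could show. The expected step is an at least 1.2-fold lower number from compound 1 to compound 4 (0.09 log units; that floor lies within the scatter). For compound 4 the estimate is 80000 nM, with an expected range from 25000 nM to 150000 nM.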

Compound 4, half-maximal inhibitory concentration: 80800 nM
For compound 4 the middle estimate is 1.0-fold (0.00 log units) below the measured one; the measured number falls inside the stated range.
By their numbers in this assay, from the lowest: compound 3; then compound 2; then compound 4. At a limit, above all of these: compound 1.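

In this assay, the exchange of 4-methoxyphenyl for 4-methylthiophen-2-yl, on an aromatic carbon of a six-membered aromatic ring with 2 nitrogen and with the carboxy group kept, is the first change shown at this position, and it gives an at least 1.2-fold lower number from compound 1 to compound 4 (0.09 log units; that floor lies within the scatter). Among these compounds, compound 4 thereby gives the first actual number for a compound that keeps the carboxy group, yet the floor of this step does not establish any real shift from the exchange. Compound 1 stands at a limit and not at a number, so the true size of the step stays unknown: the limit of > 100000 nM in this assay, at which 1 of the 4 values shown sits.

The compounds shown leave open how 4-methylthiophen-2-yl behaves alongside the carbamoyl or sulfamoyl group, where the exchange could be read against numbers on both sides instead of against a limit. They also leave open what a pyridyl group, a morpholine or a simple phenyl without the methoxy group would give at this position.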